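Swapping the ring on a urea nitrogen: solubility at low pH

The source may hold more compounds than are shown below. What is called first, only, known or untested is meant among the compounds shown, and "the series" means these compounds.

Of the compounds shown here, two have been measured in a physicochemical assay for solubility, read by nephelometry, measured as kinetic solubility, at pH 2; on this read-out higher numbers stand for higher solubility and lower numbers for lower solubility. Compound 1, `O=C(Nc1ccc(F)c(C(F)(F)F)c1)Nc1ccccn1`, gives 1.6 ug/mL. Compound 2, `Cc1cc(NC(=O)Nc2ccc(F)c(C(F)(F)F)c2)on1`, gives 12.5 ug/mL, the highest of the two numbers shown, with compound 1 as its only neighbour. Among the compounds with values here, the single measured step, a 7.8-fold higher number from compound 1 to compound 2 (0.89 log units; beyond the scatter), is the only one that bears on what follows.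

Compound 3, `O=C(Nc1cccnc1)Nc1ccc(F)c(C(F)(F)F)c1`, differs from compound 2 in one place: pyridin-3-yl in place of 3-methyl-1,2-oxazol-5-yl on an amide-type nitrogen. Within the data shown here, no measured pair covers exactly this exchange. The nearest guide is the step between compound 1 and compound 2, which replaced a pyridine ring by the 3-methyl-1,2-oxazol-5-yl ring and raised the number. Compound 3 puts a pyridine ring back, though attached through a different ring position than in compound 1, so the earlier step is a partial guide only. The expected change is therefore a drop in this assay, of a size estimated as a 2.5-fold lower number from compound 2 to compound 3 (0.40 log units; beyond the scatter), with wide uncertainty. For compound 3 the estimated value is 5 ug/mL, expected to fall between 1.5 ug/mL and 20 ug/mL.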

Compound 3, solubility: 50 ug/mL
Estimate against measurement, compound 3: 10-fold (1.00 log units) below; measured number above the stated range.
By their numbers in this assay, from the lowest: compound 1; then compound 2; then compound 3.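

In this assay, a pyridine ring on this amide-type nitrogen does not in itself go with a low number: moving the attachment from pyridin-2-yl to pyridin-3-yl gives a 31-fold higher number from compound 1 to compound 3 (1.49 log units; beyond the scatter) and is the largest step seen so far. The same ring type therefore sits at both ends of the order, and the position through which the ring is attached matters at least as much here as which ring is present. Pyridin-3-yl also outdoes the 3-methyl-1,2-oxazol-5-yl ring, with a 4.0-fold higher number from compound 2 to compound 3 (0.60 log units; beyond the scatter), so the five-membered ring holds the middle place rather than the top, and nothing measured here accounts for this order.

Still open, going by these compounds, is whether the trend carries on to pyridin-4-yl, the remaining attachment of the same ring, or holds when the pyridin-3-yl ring carries a further group such as a methyl or an amine. Also open, on these data alone, is whether the order of these three compounds would stay the same with any other group on the far side of the urea, since all three share the same fluorinated aryl half.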